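Stereocentre inversion from compound 1 to compound 4

The source may report more compounds than this note shows. Statements on the series, on what has been measured and on what is new or still open speak of the compounds shown alone.

Compound 1 `Cc1nc2cc(OC[C@H](O)CN3CCN(CC(=O)Nc4c(C)cccc4C)C[C@@H]3C)ccc2s1`: 200 nM
Compound 2 `Cc1cccc(C)c1NC(=O)CN1CCN(CC(O)COc2ccc3oc(-c4ccccc4)nc3c2)CC1`: 23000 nM
Compound 3 `Cc1nc2cc(OC[C@H](O)CN3CCN(CC(=O)Nc4c(C)cccc4C)CC3(C)C)ccc2s1`: 110 nM

In a functional assay (mitochondria) for inhibition, with Rattus norvegicus as the target (on this read-out lower numbers stand for stronger inhibition and higher numbers for weaker inhibition), compound 1 gives 200 nM. That places it at the lower end of the three numbers, together with compound 3 at 110 nM, within the scatter of it. Compound 2, at 23000 nM, lies far higher, beyond the scatter.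

Compound 4 `Cc1nc2cc(OC[C@@H](O)CN3CCN(CC(=O)Nc4c(C)cccc4C)C[C@@H]3C)ccc2s1` keeps the atoms and bonds of compound 1: the two compounds have the same atoms and bonds and differ only in configuration as drawn: 1 of 2 stereo elements differ; a stereocentre at a saturated chain carbon is drawn R in compound 1 and S in compound 4. A stereocentre at a saturated chain carbon is drawn R in compound 1 and S in compound 4. Within the data shown here, no measured pair isolates such a change, so the data offer no direct guide. No step beyond the scatter is expected in this assay, in either direction. The estimated step is no change at the digits printed from compound 1 to compound 4 (within the scatter). For compound 4 the expected value is 200 nM, with a range of 70 nM to 600 nM.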

Compound 4, half-maximal inhibitory concentration: 5000 nM
For compound 4 the middle estimate is 25-fold (1.40 log units) below the measured one; the measured number lies above the stated range.
By their numbers in this assay, from the lowest: compounds 3 and 1 (each within the scatter of the next); then compound 4; then compound 2.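

In this assay, this saturated chain carbon proves sensitive to configuration, with a 25-fold higher number from compound 1 to compound 4 (1.40 log units; beyond the scatter). The step can be assigned to this one stereocentre because nothing else separates the pair: the fact that compounds 1 and 4 differ only in the configuration as drawn. The earlier compounds shown here could not show this, as compound 1 and compound 3 are drawn alike at this carbon and compound 2 has no configuration drawn there.

As far as these compounds go, what a methoxy group or a carbonyl at this carbon would give remains open. So does whether inverting the other stereocentre of compound 1 would matter as much.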